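The source may hold more compounds than are shown below. What is called first, only, known or untested is meant among the compounds shown, and "the series" means these compounds.

Compound 1 `CC1CC/C(=N\Nc2cccc(Br)c2)c2ncc(C(=O)O)c(=O)n21` gives in a functional assay on the whole organism for inhibition, with Rattus norvegicus as the target (a lower number here means that less compound is needed, a higher number that more compound is needed for the effect), only a limit, > 320 umol/kg. Compound 2 `CC1CC/C(=N\Nc2ccc(O)cc2)c2ncc(C(=O)O)c(=O)n21` likewise gives in this assay only a limit, > 100 umol/kg. The step that the two limits leave unreadable from compound 1 to compound 2 is therefore unreadable, since both ends sit at limits. Compound 3 `CC1CC/C(=N\Nc2ccc(CC(=O)O)cc2)c2ncc(C(=O)O)c(=O)n21` differs from compound 2 by carboxymethyl in place of hydroxy on an aromatic carbon. Within the data shown here, no measured step bears on this change, and compound 2 itself stands only at a limit, so neither size nor direction can be drawn from the measured pair. Compound 3 is expected to remain near that limit, with the step that the limit leaves unreadable from compound 2 to compound 3 estimated. The estimate for compound 3 in this assay is 200 umol/kg, within 50 umol/kg to 1000 umol/kg.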

Compound 3, dose for 50% inhibition: > 100 umol/kg
Compound 3: only a limit was reported (the forecaster's own chance of this, stated with the estimate: 75%); the middle value does not contradict the limit.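

Among these compounds, compound 2 and compound 3 both stand only at a limit in this assay, so no step between them can be read: the limit of > 100 umol/kg in this assay, at which 2 of the 3 values shown sit.

The compounds shown leave open the size and direction of any change in this assay on carboxymethyl replacing hydroxy.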